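The source may hold more compounds than are shown below. What is called first, only, known or untested is meant among the compounds shown, and "the series" means these compounds.

Measured compounds, in a physicochemical assay for solubility, with a stated time of 18 h, at pH 7.4; on this read-out higher numbers stand for higher solubility and lower numbers for lower solubility:
- compound 1, `COc1cccc(CNCCCNc2ccnc3cc(Oc4ccccc4)ccc23)c1O`: 14500 nM
- compound 2, `COc1cccc(CNCCCNc2ccnc3cc(Cc4cccc(C(F)(F)F)c4)ccc23)c1O`: 4200 nM
- compound 3, `COc1cccc(CNCCCNc2ccnc3cc(Oc4cccc(N(C)C)c4)ccc23)c1O`: 14500 nM

Compound 3 stands level with compound 1 at the digits shown, the two of them together the highest of the three numbers; the one step here that lies beyond the scatter is a 3.5-fold higher number from compound 2 to compound 3 (0.54 log units; beyond the scatter), so compound 2 sits clearly apart while compound 1 and compound 3 cannot be separated.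

Compound 4, `COc1cccc(CNCCCNc2ccnc3cc(-c4ccccc4)ccc23)c1O`, has not been measured. Its change from compound 3 is phenyl in place of 3-(dimethylamino)phenoxy on an aromatic carbon.

Among the compounds with values here, two measured steps bear on this. The first, no change at the digits printed from compound 1 to compound 3 (within the scatter), removes exactly the dimethylamino that leaves here, so that part of the change carries no weight on its own. Within the data shown here, the second, a 3.5-fold lower number from compound 1 to compound 2 (0.54 log units; beyond the scatter), is the only step in which the oxygen link between the core and the pendant ring is lost; it was modest but beyond the scatter and went downward, though it also brought in a trifluoromethyl, which does not enter here. Compound 4 loses the oxygen link without gaining any substituent, so a smaller downward step than that one is expected, though the data for a bare phenyl are absent and the outcome could still fall within the scatter.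

The expected step is a 2.2-fold lower number from compound 3 to compound 4 (0.35 log units; beyond the scatter). Compound 4 is estimated at 6500 nM, within a range of 2500 nM to 15000 nM.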

Compound 4, solubility: 32000 nM
Compound 4: middle estimate off by 4.9-fold (0.69 log units), on the low side; the whole stated range lies below it.
By their numbers in this assay, from the lowest: compound 2; then compounds 1 and 3 (each within the scatter of the next); then compound 4.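

In this assay, within the data shown here, phenyl on this aromatic carbon of the shared core gives the highest number of the four compounds, with a 2.2-fold higher number from compound 1 to compound 4 (0.34 log units; beyond the scatter) and a 2.2-fold higher number from compound 3 to compound 4 (0.34 log units; beyond the scatter); the earlier compounds showed the loss of the oxygen link only in the downward step to compound 2, which also brought in a trifluoromethyl and a carbon link. With a 7.6-fold higher number from compound 2 to compound 4 (0.88 log units; beyond the scatter) as the largest step in the set, losing the oxygen link has no single direction across these compounds: compound 2 lies below compounds 1 and 3, while compound 4 lies above them. No measurement available here accounts for the upward step from the phenoxy compounds to the phenyl compound.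

The compounds shown leave open how the link and the substituent each contribute, since an unsubstituted benzyl would separate the carbon link from the trifluoromethyl, and a phenyl carrying dimethylamino would test that substituent without the oxygen link. Also open, as far as these compounds go, is whether the higher number depends on the phenyl ring itself, which a pyridine ring or a methyl on the same aromatic carbon would address.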